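The source may report more compounds than this note shows. Statements on the series, on what has been measured and on what is new or still open speak of the compounds shown alone.

The measured compounds: compound 1, `O=C(NCCCCc1ccccc1)n1nnc2ncccc21`, which in an assay on HEK293 cells for inhibition of acid ceramidase (Homo sapiens), read by fluorescence, with stated times of 30 min and 1 h (a higher number here means a weaker inhibitor, a lower number a stronger inhibitor), gives 1.3 nM; compound 2, `CCCCCCNC(=O)n1c(N)nc2ccccc21`, which in this assay gives 2.4 nM; compound 3, `CCCCCCNC(=O)N1C(=O)c2ccccc2C1=O`, which in this assay gives 7 nM.

Compound 2 stands second highest of the three numbers. Its value and that of compound 1 lie within the scatter of each other, so nothing separates them. Compound 3 lies beyond the scatter, with the higher number of that pair. Compound 4, `Cc1ccccc1CNC(=O)n1c(N)nc2ccccc21`, is not yet measured; it differs from compound 2 by 2-methylphenyl in place of pentyl on a saturated chain carbon bound to an amide-type nitrogen. Going by the values given here, no step between measured compounds that differ in one place is available, so the size of this change is not fixed by the data. In this assay a modest rise in the number is expected, and the step that this estimate means is a 3.3-fold higher number from compound 2 to compound 4 (0.52 log units; beyond the scatter), just beyond the scatter. Compound 4 is estimated at 8 nM, with a range from 2 nM to 30 nM.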

Compound 4, half-maximal inhibitory concentration: 68.4 nM
Compound 4: the middle estimate sits 8.6-fold (0.93 log units) below what was measured; the whole stated range lies below it.
By their numbers in this assay, from the lowest: compounds 1 and 2 (each within the scatter of the next); then compound 3; then compound 4.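

In this assay, 2-methylphenyl in place of pentyl on a saturated chain carbon bound to an amide-type nitrogen gives a 29-fold higher number from compound 2 to compound 4 (1.45 log units; beyond the scatter), a large step. This is the first change in a single place among these compounds, and it shows that, on the core shared by compound 2 and compound 4, the number responds strongly to the group at this position. Nothing available accounts for the size of this step. The compounds shown leave open whether the step follows the aromatic ring itself or its methyl. An unsubstituted phenyl or a longer chain such as heptyl at this position would separate these readings.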